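Swapping the amide-side ring: from compound 1 to compound 4

The source may report more compounds than this note shows. Statements on the series, on what has been measured and on what is new or still open speak of the compounds shown alone.

Measured compounds:
compound 1, `O=C(Nc1ccnnc1)c1cc(C(F)(F)F)ccc1OCc1ccccc1`: 15.9 nM
compound 2, `O=C(Nc1ccnnc1)c1cc(N2C[C@H]3COC[C@H]3C2)ccc1OCc1ccccc1`: 50.1 nM
compound 3, `O=C(Nc1ccnnc1)c1cc(N2CCCCC2)ccc1OCc1ccccc1`: 25.1 nM

All three were tested in an assay on Sf9 cells for inhibition of Leucine-rich repeat serine/threonine-protein kinase 2 (Homo sapiens), read by TR-FRET, with stated times of 30 min and 2 h; on this read-out lower numbers stand for stronger inhibition and higher numbers for weaker inhibition. Among them compound 1 stands at the lowest number, with compound 3 nearest and compound 2 furthest away; only a 3.2-fold higher number from compound 1 to compound 2 (0.50 log units; beyond the scatter) lies beyond the scatter, whereas a 1.6-fold higher number from compound 1 to compound 3 (0.20 log units; within the scatter) and a 2.0-fold lower number from compound 2 to compound 3 (0.30 log units; within the scatter) do not. Every one of these steps changes the group that sits in place of the trifluoromethyl on the shared core, and none touches the ring on the amide nitrogen.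

Compound 4, `O=C(Nc1cccc(Cl)c1)c1cc(C(F)(F)F)ccc1OCc1ccccc1`, differs from compound 1 exactly there: 3-chlorophenyl in place of pyridazin-4-yl on an amide-type nitrogen. For the measured compounds named here, no measured step bears on this kind of change, so the measured numbers give no direction for it. The expectation for compound 4 in this assay can therefore rest only on compound 1 at 15.9 nM, with a wide range to allow for a change in either direction, and it is estimated as a 5.0-fold higher number from compound 1 to compound 4 (0.70 log units; beyond the scatter). For compound 4 the expected value is 80 nM, with a likely range from 12 nM to 1500 nM.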

Compound 4, half-maximal inhibitory concentration: 25.1 nM
The estimate for compound 4 lay 3.2-fold (0.50 log units) above the measured number, within the range that was stated.
By their numbers in this assay, from the lowest: compounds 1, 3, 4 and 2 (each within the scatter of the next, the first and the last beyond it).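

For the compounds shown here, this is the first change at the ring on the amide-type nitrogen, since the earlier steps all altered the group in place of the trifluoromethyl. In this assay, the change from pyridazin-4-yl to 3-chlorophenyl gives a 1.6-fold higher number from compound 1 to compound 4 (0.20 log units; within the scatter), so on this core a carbon-only ring with a chlorine and no hydrogen-bond acceptors reads the same as a ring with two nitrogens and two acceptors, as far as the scatter allows. The ring nitrogens of pyridazin-4-yl are therefore not needed for a number in this range, at least with trifluoromethyl on the core, although nothing available here explains why the two rings read alike.

Going by these compounds, with only these two rings compared, it remains open what the chlorine contributes and whether one ring nitrogen would behave like two, questions that plain phenyl and pyridin-4-yl on the same amide-type nitrogen would address. Going by these compounds alone, it is also open whether 3-chlorophenyl would read the same on the core carrying piperidin-1-yl, or on the one carrying the two-ring group of compound 2, instead of trifluoromethyl.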